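Adding a Fluorine Next to the Acid of Compound 1

The compounds below may be only part of what the source reports. "The series", "measured", "known", "first", "only" and "open" are said of these compounds alone.

Compound 1 `Cc1c(OCCCCOc2cccc(C(=O)O)c2)ccc(C(=O)CC2CCCC2)c1O` gives the highest of the three numbers in an assay on HEK293 cells for positive allosteric modulation of metabotropic glutamate receptor 3 (Rattus norvegicus), read by thallium flux, with a stated time of 2.5 min (on this read-out higher numbers stand for larger maximal responses and lower numbers for smaller maximal responses), at 92.9%. Compound 2 `Cc1c(OCCCCOc2cccc(C(=O)O)c2)ccc(C(=O)CC(C)C)c1O` gives 69.9%, a change of a number 23 percentage points lower from compound 1 to compound 2 (beyond the scatter). Compound 3 `Cc1c(OCCCCOc2cccc(C(=O)O)c2)ccc(C(=O)CC2CCCC2)c1C` gives 16.5%, a change of a number 76.4 percentage points lower from compound 1 to compound 3 (beyond the scatter). Compound 4 `Cc1c(OCCCCOc2ccc(F)c(C(=O)O)c2)ccc(C(=O)CC2CCCC2)c1O` differs from compound 1 by fluoro in place of hydrogen on an aromatic carbon. Both measured steps alter a different part of the shared core, the ketone side chain or the hydroxy group, so neither bears directly on this change, and nothing here shows how the carboxyphenyl end tolerates a fluoro group. Among the compounds with values here, with no guiding step, the expectation for compound 4 in this assay is a step of a number 4.9 percentage points lower from compound 1 to compound 4 (within the scatter), within the scatter. Compound 4 is therefore estimated at 88%, ranging from 68% to 105%.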

Compound 4, largest response reached (reported as percent of maximum), in percent of the reference or control that the assay uses: 98.4%
For compound 4 the middle estimate is 10.4 percentage points below the measured one; low and high end bracket the measured number.
By their numbers in this assay, from the lowest: compound 3; then compound 2; then compounds 1 and 4 (each within the scatter of the next).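

In this assay, within the data shown here, the change from 3-carboxyphenyl to 3-carboxy-4-fluorophenyl gives a number 5.5 percentage points higher from compound 1 to compound 4 (within the scatter) and is the first measured change at the carboxyphenyl end. A fluoro group ortho to the carboxy group therefore keeps the response within the scatter of the parent, whereas the two earlier changes, made elsewhere on the shared core, gave steps beyond it. Nothing available explains this result.

On these data alone, it remains open whether a larger group at this position, such as chloro, methoxy or trifluoromethyl, would also be tolerated. As far as these compounds go, whether fluoro is tolerated on the other aromatic carbons of this ring also remains open.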